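Trifluoromethoxy in Place of Fluoro: Expected Inhibition of Compound 4

A few compounds are considered here, and "the series" means these few. Any claim that something is new, unique, unknown or untested is made for them only; others in the source may bear on it.

Compound 1, `Oc1ccc(-c2cc(-c3ccccc3F)cc(-c3cccc(O)c3)n2)cc1`: 6370 nM
Compound 2, `Oc1ccc(-c2cc(-c3ccccc3F)cc(-c3ccc(O)cc3)n2)cc1`: 15100 nM
Compound 3, `Oc1ccc(-c2cc(-c3cccc(C(F)(F)F)c3)cc(-c3ccc(O)cc3)n2)cc1`: > 50000 nM (a limit)
Compound 4, `Oc1ccc(-c2cc(-c3ccccc3OC(F)(F)F)cc(-c3ccc(O)cc3)n2)cc1`: not yet measured

Among the compounds with values here, in a functional assay on T47D cells (Homo sapiens) for inhibition (a lower number here means a stronger inhibitor, a higher number a weaker inhibitor), compound 2 gives 15100 nM, the higher of the two numbers measured so far. The nearest measured neighbour is compound 1, and the step of a 2.4-fold higher number from compound 1 to compound 2 (0.37 log units; beyond the scatter) lies beyond the scatter. For compound 3 the assay reports only a limit, > 50000 nM, and no number.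

Compound 4 differs from compound 2 in one place: trifluoromethoxy in place of fluoro on an aromatic carbon. The measured step that bears most directly on this change is an at least 3.3-fold higher number from compound 2 to compound 3 (0.51 log units; beyond the scatter), in which the fluorophenyl group was also altered and the result reached the assay limit (the limit of > 50000 nM in this assay, at which 1 of the 3 values shown sits). That step changes both the substituent and its place on the ring, so it is only a rough guide, but it points toward a higher number when fluoro gives way to a bulkier fluorinated group.

Compound 4 is therefore expected to be a weaker inhibitor than compound 2, with an estimated step of a 2.0-fold higher number from compound 2 to compound 4 (0.30 log units; within the scatter) in this assay. The estimate for compound 4 is 30000 nM, with a range from 12000 nM to 50000 nM.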

Compound 4, half-maximal inhibitory concentration: 9840 nM
For compound 4 the middle estimate is 3.0-fold (0.48 log units) above the measured one; the measured number lies below the stated range.
By their numbers in this assay, from the lowest: compounds 1, 4 and 2 (each within the scatter of the next, the first and the last beyond it). At a limit, above all of these: compound 3.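

In this assay, the change on an aromatic carbon ortho to a large group, from fluoro to the larger trifluoromethoxy with its added oxygen acceptor, gives a 1.5-fold lower number from compound 2 to compound 4 (0.19 log units; within the scatter), so this position accepts the larger group with no change beyond the scatter. The earlier step on this ring, an at least 3.3-fold higher number from compound 2 to compound 3 (0.51 log units; beyond the scatter), altered the group and its place together, whereas compound 4 keeps the place and shows that a larger fluorinated group there does not by itself carry the number upward. Compound 3 remains a limit and not a number, so the size of its step stays open-ended: the limit of > 50000 nM in this assay, at which 1 of the 4 values shown sits.

The compounds shown leave open whether this position would respond in the same way to an amine, a carboxylic acid or a longer alkyl chain, since both groups seen here at this place are fluorinated. They also leave open whether trifluoromethoxy would behave the same alongside the 3-hydroxyphenyl of compound 1, and whether it would hold its number if it stood where compound 3 carries its trifluoromethyl.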